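From 4-Chlorophenyl to 4-Chloro-3-fluorophenyl

This account rests on a few compounds, and the source may have more. Where it says the series, first, only, none or still open, it means among the compounds named here.

Measured so far:
compound 1 `C[C@@H]1CN(c2ccc(Cl)cc2)CCN1C(=O)C(=O)Nc1ccc2[nH]c(=O)oc2c1`: 10 mg/kg
compound 2 `C[C@@H]1CN(C(=O)C(=O)Nc2ccc3[nH]c(=O)oc3c2)CCN1c1ccc(Cl)cc1`: 10 mg/kg

Both measured compounds were tested in a functional assay on the whole organism with Rattus norvegicus as the target, with a stated time of 3 h; on this read-out lower numbers stand for an effect already at smaller amounts and higher numbers for an effect only at larger amounts of compound. Compound 1 stands level with compound 2 at the digits shown, and the two values lie within the usual scatter of each other, so no order can be read between them. Compound 3 `C[C@@H]1CN(c2ccc(Cl)c(F)c2)CCN1C(=O)C(=O)Nc1ccc2[nH]c(=O)oc2c1` has not been measured. It differs from compound 1 in one place: fluoro in place of hydrogen on an aromatic carbon. Among the measured compounds shown here, no step between measured compounds carries this change, so the data give no direction for it. In this assay the expected step is no change at the digits printed from compound 1 to compound 3 (within the scatter), none beyond the scatter. Compound 3 is therefore estimated at 10 mg/kg, between 5 mg/kg and 20 mg/kg.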

Compound 3, minimum effective dose: 5 mg/kg
Estimate against measurement, compound 3: 2.0-fold (0.30 log units) above; measured number inside the range.
By their numbers in this assay, from the lowest: compounds 3, 1 and 2 (each within the scatter of the next).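

In this assay, fluoro in place of hydrogen on the aromatic carbon ortho to a chloro group gives a 2.0-fold lower number from compound 1 to compound 3 (0.30 log units; within the scatter), so the ring carries this extra atom with no shift that stands clear of the usual scatter. No measurement shown offers an explanation for this result. Still open, from the compounds shown here alone, is how a larger group on the same carbon, such as methoxy, a nitrile or an amine, would read, and whether the same fluoro would read alike on compound 2.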